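Working notes: from 2-nitrophenyl to 3-nitrophenyl

The compounds below may be only part of what the source reports. "The series", "measured", "known", "first", "only" and "open" are said of these compounds alone.

- compound 1 `CC1=CC[C@@H]([C@@](C)(O)CCCC(C)(C)NC(=S)N/N=C\c2ccc(O)cc2)CC1` gives 600 nM in a functional assay on K562 cells (Homo sapiens) for cytotoxicity, read by sulforhodamine B assay; on this read-out higher numbers stand for weaker inhibition of growth and lower numbers for stronger inhibition of growth
- compound 2 `CC1=CC[C@@H]([C@@](C)(O)CCCC(C)(C)NC(=S)N/N=C\c2ccccc2[N+](=O)[O-])CC1` gives 190 nM in this assay

Of the two measured compounds, compound 2 at 190 nM has the lower number and so the stronger inhibition of growth. The next compound to consider is compound 3 `CC1=CC[C@@H]([C@@](C)(O)CCCC(C)(C)NC(=S)N/N=C\c2cccc([N+](=O)[O-])c2)CC1`, which has not yet been measured in this assay and differs from compound 2 as follows: 3-nitrophenyl in place of 2-nitrophenyl on a carbon with a double bond to nitrogen. In words, this is 3-nitrophenyl in place of 2-nitrophenyl on a carbon with a double bond to nitrogen.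

Among the measured compounds shown here, only one measured step bears on this change, and only indirectly. That step is a 3.2-fold lower number from compound 1 to compound 2 (0.50 log units; beyond the scatter), a modest change beyond the scatter, and it replaces 4-hydroxyphenyl with 2-nitrophenyl. For the measured compounds named here, no measured pair compares two nitrophenyl groups, so the direction of the coming step remains open. A change no larger than that modest step is expected, and probably one within the scatter. The estimated step is a 1.3-fold higher number from compound 2 to compound 3 (0.12 log units; within the scatter) in this assay on present evidence. The expected value for compound 3 is 250 nM, with an estimated range of 100 nM to 600 nM.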

Compound 3, concentration for 50% growth inhibition: 20 nM
Compound 3: the middle estimate sits 13-fold (1.10 log units) above what was measured, outside the stated range (below it).
By their numbers in this assay, from the lowest: compound 3; then compound 2; then compound 1.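

In this assay, the step from 2-nitrophenyl to 3-nitrophenyl on the carbon with a double bond to nitrogen is a 9.5-fold lower number from compound 2 to compound 3 (0.98 log units; beyond the scatter), and since the two groups have the same atoms joined differently, this read-out depends on how the nitrophenyl group is joined and not only on which atoms it holds. Compared with the 4-hydroxyphenyl group, 3-nitrophenyl gives a 30-fold lower number from compound 1 to compound 3 (1.48 log units; beyond the scatter), a large step that goes well past the modest 3.2-fold lower number from compound 1 to compound 2 (0.50 log units; beyond the scatter), so the earlier comparison of compound 1 with compound 2 understated how far a change at this place can move the number. Nothing measured on these compounds accounts for the gap between the two nitrophenyl isomers.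

The compounds shown do not tell whether the low number of compound 3 needs the nitro group itself, or whether an amine, a nitrile or a carboxylic acid on the phenyl ring would keep it. They also leave open whether the difference between the isomers would hold on the shared core with the thiourea-linked chain changed, for instance with a longer chain.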